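From Chloro to Bromo in a Small Set

This account rests on a few compounds, and the source may have more. Where it says the series, first, only, none or still open, it means among the compounds named here.

In a functional assay on MOLT-4 cells (Homo sapiens) for inhibition (on this read-out higher numbers stand for weaker inhibition and lower numbers for stronger inhibition), compound 3 (`O=C1/C(=C/c2ccc(Cl)cc2)CCCc2ccccc21`) gives 33000 nM and so lies within the scatter of compound 2 (`O=C1/C(=C/c2ccc(F)cc2)CCCc2ccccc21`) at 53600 nM in this small set. Compound 1 (`CN(C)c1ccc(/C=C2\CCc3ccccc3C2=O)cc1`) stands clearly lower with 2110 nM as its number. Compound 4 (`O=C1/C(=C/c2ccc(Br)cc2)CCCc2ccccc21`) differs from compound 3 in one place (bromo in place of chloro on an aromatic carbon): bromo in place of chloro on an aromatic carbon. Going by the values given here, the one measured step of this kind (a 1.6-fold lower number from compound 2 to compound 3 (0.21 log units; within the scatter)) put chloro in place of fluoro and stayed within the scatter. No shift beyond the scatter is therefore expected in this assay here. The expected step is a 1.2-fold lower number from compound 3 to compound 4 (0.07 log units; within the scatter) and stays within the scatter. Compound 4 is estimated at 28000 nM with a range from 12000 nM to 60000 nM as its likely span.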

Compound 4, half-maximal inhibitory concentration: 54700 nM
Compound 4: the middle estimate sits 2.0-fold (0.29 log units) below what was measured; the range from low to high includes it.
By their numbers in this assay, from the lowest: compound 1; then compounds 3, 2 and 4 (each within the scatter of the next).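

In this assay bromo in place of chloro gives no separation (a 1.7-fold higher number from compound 3 to compound 4 (0.22 log units; within the scatter)), and neither does bromo in place of fluoro (a 1.0-fold higher number from compound 2 to compound 4 (0.01 log units; within the scatter)). Fluoro, chloro and bromo on this aromatic carbon therefore read alike across compound 2, compound 3 and compound 4, so swapping among these three groups here does not separate the numbers. Nothing available explains this result. Still open, going by these compounds, is how a methoxy group, an amine or a carboxylic acid would read at this same place on the shared core.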